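Halogen exchange on the fused core: chloro to bromo

This account rests on a few compounds, and the source may have more. Where it says the series, first, only, none or still open, it means among the compounds named here.

Compound 1 `O=C(O)Cn1c(=O)c(/C=C/c2ccc(O)c(O)c2)nc2cc(Cl)cnc21` gives 87.4% in a functional assay, read by spectrophotometry, with a stated time of 30 min, tested at 50 uM; on this read-out higher numbers stand for a stronger effect at the one concentration tested and lower numbers for a weaker effect. Among the compounds with values here, compound 2 `COc1cc(/C=C/c2nc3cc(Cl)cnc3n(CC(=O)O)c2=O)ccc1O` gives 81.8% in this assay, and the one measured step, a number 5.6 percentage points lower from compound 1 to compound 2 (within the scatter), covers methyl in place of hydrogen on an oxygen on an aromatic ring. On these two numbers compound 1 and compound 2 sit within the scatter of each other, so no ranking between them is supported.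

Compound 3 `O=C(O)Cn1c(=O)c(/C=C/c2ccc(O)c(O)c2)nc2cc(Br)cnc21` is to be measured. Its difference from compound 1: bromo in place of chloro on an aromatic carbon. Within the data shown here, no measured step touches the halogen on the fused core; the only step available concerns a different part of the molecule and stayed within the scatter. With nothing pointing either way, the step of a number 2.4 percentage points lower from compound 1 to compound 3 (within the scatter) is expected to stay within the scatter. Compound 3 is therefore estimated at 85%, with a range from 70% to 95%.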

Compound 3, a percentage reported as activity, at one concentration (the size of the read-out at that concentration, not a potency): 82.4%
The estimate for compound 3 lay 2.6 percentage points above the measured number, and the stated range covers the measured number.
By their numbers in this assay, from the lowest: compounds 2, 3 and 1 (each within the scatter of the next).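

Bromo in place of chloro on an aromatic carbon of the six-membered aromatic ring with 1 nitrogen is the first change shown at the halogen on the shared core, and in this assay it gives a number 5 percentage points lower from compound 1 to compound 3 (within the scatter). The read-out therefore does not separate chloro from bromo at this position, so the position accepts either of these two halogens without a change beyond the scatter. No available measurement bears on why the two halogens read alike.

As far as these compounds go, whether this holds beyond halogens stays open, as an amine, a methoxy or a nitrile on this carbon would test the position with a group of another kind. From the compounds shown here alone, the readings come from one concentration, so whether chloro and bromo would differ at any other concentration also remains open.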